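This account rests on a few compounds, and the source may have more. Where it says the series, first, only, none or still open, it means among the compounds named here.

Values in an in vitro ADME assay on microsomes from liver (Homo sapiens) for metabolic stability (on this read-out higher numbers stand for fast clearance and lower numbers for slow clearance), for the compounds in this series:

Compound 1 `Fc1ccccc1Cc1nc(-c2nc(C(F)F)n[nH]2)n2ccccc12` gives 62 mL.min-1.g-1
Compound 2 `NC(=O)c1n[nH]c(-c2nc(Cc3ccccc3F)c3ccccn23)n1` gives < 8 mL.min-1.g-1, which is a limit of the assay
Compound 3 `Cc1ncc(Cn2nc(-c3nc(C(F)(F)F)n[nH]3)c3cccnc32)cn1` gives < 7 mL.min-1.g-1, which is a limit of the assay
Compound 4 `Cc1n[nH]c(-c2nc(Cc3ccccc3F)c3ccccn23)n1` has not yet been measured

Compound 2 has no exact number in this assay, and its reading of < 8 mL.min-1.g-1 is a limit. Among the compounds with values here, compound 3 also reads as a limit, but no single change connects it with the other compounds, so it gives no step to work from.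

The move from compound 2 to compound 4 is methyl in place of carbamoyl on an aromatic carbon, which puts methyl in place of carbamoyl on an aromatic carbon, between two ring nitrogen atoms. Within the data shown here, one measured step bears on this. Carbamoyl in place of difluoromethyl on an aromatic carbon gave an at least 7.7-fold lower number from compound 1 to compound 2 (0.88 log units; beyond the scatter), a change beyond the scatter. Compound 4 gives up that carbamoyl, so a rise in the number is expected, although methyl is not difluoromethyl and the full size of that step need not return. The starting point is a limit. The size of the rise remains loose.

The expected change is an at least 3.1-fold higher number from compound 2 to compound 4 (0.49 log units; beyond the scatter), towards faster clearance. For compound 4 the estimated value is 25 mL.min-1.g-1, with an expected range from 10 mL.min-1.g-1 to 60 mL.min-1.g-1.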

Compound 4, intrinsic clearance in microsomes: 124 mL.min-1.g-1
For compound 4 the middle estimate is 5.0-fold (0.70 log units) below the measured one; the whole stated range lies below it.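

In this assay, the position on the aromatic carbon between two ring nitrogen atoms now has a direct comparison for carbamoyl on the core of compound 2: methyl in its place gives an at least 15-fold higher number from compound 2 to compound 4 (1.19 log units; beyond the scatter). The other new step, a 2.0-fold higher number from compound 1 to compound 4 (0.30 log units; within the scatter), lies within the scatter, so methyl and difluoromethyl do not separate at this position, and among the three groups shown only carbamoyl stands apart, with the low reading tied to its presence rather than to the loss of difluoromethyl alone. The reading of compound 2 is a limit, so the rise to compound 4 is known only as a lower bound and its full size cannot be stated: the limit of < 8 mL.min-1.g-1 in this assay, at which 1 of the 4 values shown sits.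

From the compounds shown here alone, it remains open whether the low reading belongs to carbamoyl alone or would also appear with another group at this position, such as a carboxylic acid, an amine or a nitrile. Within the data shown here, it also remains open whether carbamoyl has a comparable effect on the core of compound 3, which differs from the other compounds in more than one place and so gives no step.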